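From Pentyl to Iodo on the Aromatic Ring

A few compounds are considered here, and "the series" means these few. Any claim that something is new, unique, unknown or untested is made for them only; others in the source may bear on it.

Of the compounds shown here, three have been measured in an ADME assay on the whole organism with Oryza sativa as the target, tested at 0.1 uM; on this read-out lower numbers stand for a stronger effect and higher numbers for a weaker effect at the one concentration tested. Compound 1 `Cc1cccc(NC(=O)N[C@H](C)c2ccccc2)c1` gives 100%. Compound 2 `CCCCCc1ccc(NC(=O)N[C@H](C)c2ccccc2)cc1` gives 100%, and compound 3 `CCCCCc1ccc(NC(=O)N[C@@H](C)c2ccccc2)cc1` gives 98%. Compound 2 is level with compound 1 at the digits shown, and together they are the highest of the three numbers, although compound 3 lies within the scatter of both. For the measured compounds named here, the only measured step between two compounds that differ in a single place is a number 2 percentage points lower from compound 2 to compound 3 (within the scatter), and it stays within the scatter; this is unsurprising because of the fact that compounds 2 and 3 differ only in the configuration as drawn, the two sharing every atom and bond.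

The step to follow leads from compound 2 to compound 4 `C[C@@H](NC(=O)Nc1ccc(I)cc1)c1ccccc1`, with iodo in place of pentyl on an aromatic carbon. Going by the values given here, no measured step involves a change of this kind, so the measured step offers no direct guide, and all three numbers already sit at or near the top of the scale, leaving little room upward. Compound 4 is expected to give 98%, between 85% and 100%. That expectation amounts to a number 2 percentage points lower from compound 2 to compound 4 (within the scatter), a step within the scatter.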

Compound 4, a percentage reported as activity, at one concentration (the size of the read-out at that concentration, not a potency): 100%
For compound 4 the middle estimate is 2 percentage points below the measured one; measured number inside the range.
By their numbers in this assay, from the lowest: compounds 3, 1, 2 and 4 (each within the scatter of the next).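

In this assay, for the compounds shown here, putting iodo in place of pentyl on an aromatic carbon, para to a large group, gives no change at the digits printed from compound 2 to compound 4 (within the scatter) and is the first measured step that replaces a group rather than altering a configuration as drawn. A pentyl chain of 5 heavy atoms and an iodo group of 1 heavy atom therefore cannot be told apart at this position by this read-out at the one concentration tested. The information available offers no explanation for this result.

On these data alone, whether an amine or a carboxylic acid on the same aromatic carbon would shift the number remains open. As far as these compounds go, it is also open whether any group at this position can bring the number clearly down, since all four compounds lie within the scatter of the next.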